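The source may hold more compounds than are shown below. What is called first, only, known or untested is meant among the compounds shown, and "the series" means these compounds.

Compound 1 `COc1cc(N)c(Cl)cc1C(=O)NC1CCN(CC2CCN(C(=O)C(C)(C)N)CC2)CC1`: 2.6 nM
Compound 2 `COc1cc(N)c(Cl)cc1C(=O)NC1CCN(C(=O)C2CCN(C(=O)CCCN)CC2)CC1`: 425 nM

Going by the values given here, in an assay on striatum for inhibition of 5-hydroxytryptamine receptor 4 (Cavia porcellus), read by radioligand binding (a higher number here means a weaker inhibitor, a lower number a stronger inhibitor), compound 1 gives 2.6 nM, the lower of the two numbers measured so far. Compound 2 gives 425 nM, and the gap between the two compounds lies well beyond the scatter. Compound 2 differs from compound 1 in more than one place, so its number cannot be pinned on any single change and offers no direct guide to a one-place step.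

Compound 3 `COc1cc(N)c(Cl)cc1C(=O)NC1CCN(CC2CCN(C(=O)CCN)CC2)CC1` has not yet been measured. It differs from compound 1 in one place only: 2-aminoethyl in place of 1-amino-1-methylethyl on a carbonyl carbon. Both the group that leaves and the group that enters carry one amine, and the entering group is the smaller of the two, as the counts show.

Among the compounds with values here, no pair of measured compounds differs in a single place, so no measured step exists to lean on. A change of this modest size is expected to shift the number in this assay only slightly, if at all, so the step from compound 1 to compound 3 is expected to be a 1.9-fold higher number from compound 1 to compound 3 (0.28 log units; within the scatter), leaning toward a somewhat higher number. Compound 3 is therefore estimated at 5 nM, with a range from 1.5 nM to 16 nM.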

Compound 3, half-maximal inhibitory concentration: 9.5 nM
Estimate against measurement, compound 3: 1.9-fold (0.28 log units) below; the range from low to high includes it.
By their numbers in this assay, from the lowest: compound 1; then compound 3; then compound 2.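

Going by these compounds alone, this is the first step that can be read at a single place: in this assay, putting 2-aminoethyl in place of 1-amino-1-methylethyl on the carbonyl carbon gives a 3.7-fold higher number from compound 1 to compound 3 (0.56 log units; beyond the scatter), so this group does have a measurable bearing on the number. The step is modest, and compound 3 still gives 9.5 nM, so the position accepts this smaller group with only a limited loss, even though the change lies beyond the scatter. Both groups carry one amine, one hydrogen-bond donor and one hydrogen-bond acceptor, and no measured data explain the step.

The compounds shown leave open whether the size of the group, the place of its amine or the two together set this step, as one single-place change cannot separate them. Also open, from the compounds shown here alone, is how a longer chain such as 3-aminopropyl, or a carboxylic acid in place of the amine, would read on this same carbonyl carbon in this assay.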